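The source may report more compounds than this note shows. Statements on the series, on what has been measured and on what is new or still open speak of the compounds shown alone.

Measured compounds:
- compound 1, `NS(=O)(=O)c1ccc(NC(=S)Nc2ccc3ncnc(Nc4ccc(Cl)c(C(F)(F)F)c4)c3c2)cc1`: 11800 nM
- compound 2, `NS(=O)(=O)c1ccc(NC(=S)Nc2ccc3ncnc(Nc4ccc(F)c(Br)c4)c3c2)cc1`: 9980 nM
- compound 3, `NS(=O)(=O)c1ccc(NC(=S)Nc2ccc3ncnc(Nc4ccc(C(F)(F)F)cc4)c3c2)cc1`: 17100 nM

All three share one core and differ only in the aryl group on a nitrogen on an aromatic ring. In a functional assay on NCI-H1975 cells (Homo sapiens) for antiproliferative activity, read by MTT assay, with a stated time of 72 h (a lower number here means a stronger inhibitor, a higher number a weaker inhibitor), compound 3 gives the highest of the three numbers, yet the steps that reach it, a 1.4-fold higher number from compound 1 to compound 3 (0.16 log units; within the scatter) and a 1.7-fold higher number from compound 2 to compound 3 (0.23 log units; within the scatter), both fall within the scatter, as does a 1.2-fold lower number from compound 1 to compound 2 (0.07 log units; within the scatter). Nothing in these three compounds separates one aryl group from another beyond the noise of this assay.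

Compound 4, `NS(=O)(=O)c1ccc(NC(=S)Nc2ccc3ncnc(Nc4cccc(Cl)c4)c3c2)cc1`, has not yet been measured. It differs from compound 3 by 3-chlorophenyl in place of 4-(trifluoromethyl)phenyl on a nitrogen on an aromatic ring. The two measured steps that bear on this change are those from compound 1 and compound 2 to compound 3, each of which exchanged one substituted phenyl for another and each of which stayed within the scatter. On that basis the step from compound 3 to compound 4 is expected to be small, with at most a slight move toward a lower number, since the phenyl groups carrying a substituent in the 3-position gave the lower numbers, the expected step being a 1.4-fold lower number from compound 3 to compound 4 (0.14 log units; within the scatter). Compound 4 is therefore estimated at 12500 nM, within a range from 6000 nM to 28000 nM.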

Compound 4, half-maximal inhibitory concentration: 39800 nM
Compound 4: middle estimate off by 3.2-fold (0.50 log units), on the low side; the whole stated range lies below it.
By their numbers in this assay, from the lowest: compounds 2, 1 and 3 (each within the scatter of the next); then compound 4.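

At this place, on a nitrogen on an aromatic ring, the aryl group does move the number beyond the scatter in this assay, which the first three compounds never showed: 3-chlorophenyl gives a 2.3-fold higher number from compound 3 to compound 4 (0.37 log units; beyond the scatter), a 4.0-fold higher number from compound 2 to compound 4 (0.60 log units; beyond the scatter) and a 3.4-fold higher number from compound 1 to compound 4 (0.53 log units; beyond the scatter). Of the four aryl groups, 3-chlorophenyl is the only one without a substituent named at the 4-position, and it alone stands apart, whereas 3-bromo-4-fluorophenyl, 4-chloro-3-(trifluoromethyl)phenyl and 4-(trifluoromethyl)phenyl remain within the scatter of one another, so a group in the 3-position does not by itself go with a lower number here. Nothing measured on these compounds accounts for this separation, and the link with the 4-position remains an observation on four compounds only.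

Going by these compounds, what stays open is whether the higher number of compound 4 follows from the empty 4-position or from the chlorine itself, a question that 4-chlorophenyl or unsubstituted phenyl in the same place would address. On these data alone, it is also open whether an aryl group carrying an amine or a carboxylic acid at this place would bring the number down, or whether this position only offers ways of raising it.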